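Swapping a ring amine for an anilino group on the shared core

The source may hold more compounds than are shown below. What is called first, only, known or untested is meant among the compounds shown, and "the series" means these compounds.

Of the compounds shown here, two built on the same core have been tested in a functional assay on PC-3 cells (Homo sapiens) for inhibition, with a stated time of 72 h; a higher number here means a weaker inhibitor, a lower number a stronger inhibitor. Compound 1 `O=C(Nc1ccccc1)Nc1nc(NC2CC2)cc(Sc2c[nH]c3ccccc23)n1` gives 17500 nM. Compound 2 `O=C(Nc1ccccc1)Nc1nc(Sc2c[nH]c3ccccc23)cc(N2CCCC2)n1` gives 14900 nM. Within the data shown here, the change a 1.2-fold lower number from compound 1 to compound 2 (0.07 log units; within the scatter) is the only step measured so far, and it does not separate the two compounds. Compound 2 thus holds the lower of the two numbers, but only by a margin within the scatter, so no ranking can be claimed between compound 1 and compound 2.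

Compound 3 `O=C(Nc1ccccc1)Nc1nc(Nc2ccccc2)cc(Sc2c[nH]c3ccccc23)n1` has not yet been tested. It differs from compound 2 in one place: anilino in place of pyrrolidin-1-yl on an aromatic carbon. Among the measured compounds shown here, the single measured step, from a cyclopropylamino to a pyrrolidin-1-yl group, changed little, and it does not involve an anilino group, so it gives only weak guidance for this new change. With nothing in the measured steps pointing either way, compound 3 is expected to land close to compound 2, a step of a 1.2-fold lower number from compound 2 to compound 3 (0.09 log units; within the scatter) in this assay. The estimate for compound 3 is therefore 12000 nM, with a range from 4000 nM to 40000 nM.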

Compound 3, half-maximal inhibitory concentration: 26400 nM
For compound 3 the middle estimate is 2.2-fold (0.34 log units) below the measured one, and the stated range covers the measured number.
By their numbers in this assay, from the lowest: compounds 2, 1 and 3 (each within the scatter of the next).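

At this position on the shared core, this assay now covers an aromatic group as well as two saturated rings: anilino in place of pyrrolidin-1-yl gives a 1.8-fold higher number from compound 2 to compound 3 (0.25 log units; within the scatter), and phenyl in place of cyclopropyl on the nitrogen gives a 1.5-fold higher number from compound 1 to compound 3 (0.18 log units; within the scatter). The position has thus carried a cyclopropylamino, a pyrrolidin-1-yl and an anilino group, with a six-membered aromatic ring entering and a hydrogen-bond donor present in the anilino group but absent from pyrrolidin-1-yl, yet all three compounds lie within the scatter of one another and this read-out does not separate them. No evidence is available on why the three numbers lie so close together.

The compounds shown leave open whether a morpholine ring, an open-chain dimethylamino group or an anilino group carrying a fluorine or a methoxy group at this position would give a step beyond the scatter. They also leave open whether a change elsewhere, in the (phenylcarbamoyl)amino group or the (1H-indol-3-yl)sulfanyl group, would move the number further than any change at this position has so far.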